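Urea series: aryl swap on the triazole nitrogen

This account rests on a few compounds, and the source may have more. Where it says the series, first, only, none or still open, it means among the compounds named here.

compound 1 `N#Cc1ccccc1-n1cc(COc2cccc(NC(=O)Nc3ccc(Cl)c(C(F)(F)F)c3)c2)nn1` — 17500 nM
compound 2 `N#Cc1cccc(-n2cc(COc3cccc(NC(=O)Nc4ccc(Cl)c(C(F)(F)F)c4)c3)nn2)c1` — 2960 nM

Among the compounds with values here, in a toxicity assay on MRC5 cells (Homo sapiens) for inhibition, read by MTT assay, with a stated time of 72 h (a higher number here means a weaker inhibitor, a lower number a stronger inhibitor), compound 2 stands lowest of the two numbers; the single measured step, a 5.9-fold lower number from compound 1 to compound 2 (0.77 log units; beyond the scatter), separates it from the other. Compound 3 `O=C(Nc1cccc(OCc2cn(-c3ccc(F)cc3)nn2)c1)Nc1ccc(Cl)c(C(F)(F)F)c1` carries 4-fluorophenyl in place of 3-cyanophenyl on an aromatic nitrogen. Within the data shown here, the one measured step moves only the nitrile around the ring, so nothing measured bears on removing the nitrile or bringing in fluorine; it shows only that this aryl group can shift this assay by a modest amount. Compound 3 is therefore expected near 5000 nM, within 1500 nM to 20000 nM. The expected step of a 1.7-fold higher number from compound 2 to compound 3 (0.23 log units; within the scatter) is estimated to stay within the scatter.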

Compound 3, half-maximal inhibitory concentration: 4740 nM
The estimate for compound 3 lay 1.1-fold (0.02 log units) above the measured number, within the range that was stated.
By their numbers in this assay, from the lowest: compounds 2 and 3 (each within the scatter of the next); then compound 1.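

In this assay the nitrile is not required for the lower numbers: the 4-fluorophenyl group gives a 1.6-fold higher number from compound 2 to compound 3 (0.20 log units; within the scatter) and so stays within the scatter of 3-cyanophenyl. Only the 2-cyanophenyl group stands apart, as a 3.7-fold lower number from compound 1 to compound 3 (0.57 log units; beyond the scatter) shows. Nothing available here accounts for these steps.

Still open, on these data alone, is whether the number for compound 1 follows from the nitrile at that ring position or from any group placed there. Also open, as far as these compounds go, is how this assay responds to an amine or a carboxylic acid on the aryl ring, or to a cyclohexyl group replacing it.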